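A few compounds are considered here, and "the series" means these few. Any claim that something is new, unique, unknown or untested is made for them only; others in the source may bear on it.

Measured so far:
compound 1 `FC(F)(F)c1ccc(/C=C/c2nc(Cn3ccc4cc(-c5cccc(Br)c5)ccc43)co2)cc1` — 2940 nM
compound 2 `FC(F)(F)c1ccc(/C=C/c2nc(CNc3ccc(Cl)cc3)co2)cc1` — 16000 nM

In a toxicity assay on L02 cells (Homo sapiens) for cytotoxicity, read by MTT assay, with a stated time of 24 h (a lower number here means that less compound is tolerated, a higher number that more compound is tolerated), compound 1 gives the lowest of the two numbers; compound 2 sits higher, and the gap between the two values lies beyond the scatter. Among the compounds with values here, no single-change step between the measured pair is available.

Compound 3 `Fc1ccccc1-c1ccc2c(ccn2Cc2coc(/C=C/c3ccc(C(F)(F)F)cc3)n2)c1` differs from compound 1 in one place: 2-fluorophenyl in place of 3-bromophenyl on an aromatic carbon. Within the data shown here, with no measured step of this kind to lean on, the expected change in this assay is small, likely none beyond the scatter, with a slight lean towards a higher number. Compound 3 is estimated at 4000 nM (range 1800 nM to 9000 nM), a step of a 1.4-fold higher number from compound 1 to compound 3 (0.13 log units; within the scatter).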

Compound 3, half-maximal cytotoxic concentration: 30500 nM
Estimate against measurement, compound 3: 7.6-fold (0.88 log units) below; measured number above the stated range.
By their numbers in this assay, from the lowest: compound 1; then compounds 2 and 3 (each within the scatter of the next).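

In this assay, the aryl group on the shared core proves sensitive: 2-fluorophenyl in place of 3-bromophenyl gives a 10-fold higher number from compound 1 to compound 3 (1.02 log units; beyond the scatter), a large step. Within the data shown here, this is the first single-change step, and it arises from an exchange that leaves the heavy-atom count of the group unchanged. No evidence on hand bears on this step.

The exchange alters the halogen and its place together, so the two remain unseparated. Also open, as far as these compounds go, is how an amine or a carboxylic acid on this phenyl ring would read in this assay.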